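Replacing methoxy with fluoro on the pendant phenyl ring

The source may report more compounds than this note shows. Statements on the series, on what has been measured and on what is new or still open speak of the compounds shown alone.

Measured compounds:
Compound 1, `O=Cc1ccc(-c2cn3ccnc3c(-c3ccc4ncn(C5CCCCC5)c4c3)n2)cc1`, in a functional assay on SR cells (Homo sapiens) for inhibition, read by sulforhodamine B assay, with a stated time of 48 h, tested at 10 uM (a lower number here means less inhibition, a higher number more inhibition at the concentration tested (going by the name of the read-out)), compound 1 gives 47.5%.
Compound 2, `Fc1ccc(-c2cn3ccnc3c(-c3ccc4ncn(C5CCCCC5)c4c3)n2)cc1`, in this assay compound 2 gives 20.4%.
Compound 3, `COc1ccccc1-c1cn2ccnc2c(-c2ccc3ncn(C4CCCCC4)c3c2)n1`, in this assay compound 3 gives 26.3%.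

Compound 3 stands second highest of the three numbers. Its nearest neighbour is compound 2, and that gap is a number 5.9 percentage points higher from compound 2 to compound 3 (within the scatter). Compound 1 lies furthest away, and the step from compound 1 to compound 3 is a number 21.2 percentage points lower from compound 1 to compound 3 (beyond the scatter).

Compound 4, `Fc1ccccc1-c1cn2ccnc2c(-c2ccc3ncn(C4CCCCC4)c3c2)n1`, is not yet measured. It differs from compound 3 by fluoro in place of methoxy on an aromatic carbon.

Among the measured compounds shown here, two measured steps bear on this. The step of a number 27.1 percentage points lower from compound 1 to compound 2 (beyond the scatter) shows that a change on the pendant phenyl ring can move the number by a modest amount, while a number 5.9 percentage points higher from compound 2 to compound 3 (within the scatter) shows that exchanging the whole substituted phenyl can also leave it within the scatter. For the measured compounds named here, no measured pair exchanges methoxy for fluoro at the same place, so the direction is uncertain. The step from compound 3 to compound 4 is expected to be a number 2.3 percentage points lower from compound 3 to compound 4 (within the scatter), within the scatter. Compound 4 is therefore estimated at 24%, between 10% and 38%.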

Compound 4, a percentage reported as inhibition, at one concentration (the size of the read-out at that concentration, not a potency): 16.3%
Compound 4: middle estimate off by 7.7 percentage points, on the high side; the range from low to high includes it.
By their numbers in this assay, from the lowest: compounds 4, 2 and 3 (each within the scatter of the next); then compound 1.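

In this assay the exchange of methoxy for fluoro on this aromatic carbon, ortho to a large group, gives a number 10 percentage points lower from compound 3 to compound 4 (within the scatter) and so does not move the number beyond the scatter at this place. Fluoro's place on the pendant phenyl ring also shows no effect beyond the scatter, since 2-fluorophenyl in place of 4-fluorophenyl gives a number 4.1 percentage points lower from compound 2 to compound 4 (within the scatter) and leaves these two compounds together. The step to 2-fluorophenyl from 4-formylphenyl gives a number 31.2 percentage points lower from compound 1 to compound 4 (beyond the scatter) and adds to the picture in which compound 1 alone stands apart among the four compounds.

On these data alone, whether an amine or a carboxylic acid on the pendant phenyl ring would stand with compound 1 or with the other three stays open. Nothing at hand says why compound 1 stands apart.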